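The source may hold more compounds than are shown below. What is called first, only, known or untested is meant among the compounds shown, and "the series" means these compounds.

Three close analogues of one shared core have been measured in a functional assay on isolated protein for inhibition of Glucose-dependent insulinotropic receptor (Rattus norvegicus), read by HTRF and cAMP accumulation; a higher number here means that more compound is needed for the effect, a lower number that less compound is needed. Compound 3 `Cc1nc(S(C)(=O)=O)ccc1Oc1ncnc(OC2CCN(C(=O)SC(C)C)CC2)c1F` gives 41.3 nM, the lowest of the three numbers shown, though within the scatter of both others: compound 1 `Cc1nc(S(C)(=O)=O)ccc1Oc1ncnc(OC2CCN(C(=O)OC(C)(C)C(F)(F)F)CC2)c1F` gives 47.2 nM and compound 2 `Cc1nc(S(C)(=O)=O)ccc1Oc1ncnc(OC2CCN(C(=O)OC3(C(F)(F)F)CCC3)CC2)c1F` gives 63.3 nM. Compound 4 `Cc1nc(S(C)(=O)=O)ccc1Oc1ncnc(OC2CCN(C(=O)C3(F)CCC3)CC2)c1F` differs from compound 3 by a group of 5 heavy atoms (4 carbon, 1 fluorine; one four-membered non-aromatic ring of carbon only) in place of a group of 4 heavy atoms (3 carbon, 1 sulfur; no ring), on a carbonyl carbon. For the measured compounds named here, the steps that bear on this change at the same carbonyl carbon, a 1.5-fold lower number from compound 2 to compound 3 (0.19 log units; within the scatter) and a 1.1-fold lower number from compound 1 to compound 3 (0.06 log units; within the scatter), together with a 1.3-fold higher number from compound 1 to compound 2 (0.13 log units; within the scatter), all fall within the scatter, so varying this group has so far left the number essentially unchanged. For compound 4 a step no larger than the scatter is therefore expected, a 1.2-fold higher number from compound 3 to compound 4 (0.08 log units; within the scatter). Compound 4 is estimated at 50 nM, with a range from 20 nM to 125 nM.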

Compound 4, half-maximal effective concentration: 123 nM
Estimate against measurement, compound 4: 2.5-fold (0.39 log units) below, and the stated range covers the measured number.
By their numbers in this assay, from the lowest: compounds 3, 1, 2 and 4 (each within the scatter of the next, the first and the last beyond it).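

In this assay, for the compounds shown here, this carbonyl carbon proves less tolerant than the earlier compounds suggested: the group of 5 heavy atoms brings a 3.0-fold higher number from compound 3 to compound 4 (0.47 log units; beyond the scatter) and also a 2.6-fold higher number from compound 1 to compound 4 (0.42 log units; beyond the scatter) and both of these lie beyond the scatter, while a 1.9-fold higher number from compound 2 to compound 4 (0.29 log units; within the scatter) stays within it. Varying this group can therefore shift the number modestly, with compound 2 going against any clean separation of compound 4 from the rest. Nothing measured here accounts for the shift. Still open, from the compounds shown here alone, is how the four-membered carbon ring without its fluorine would read at this carbonyl carbon, and how an amine nitrogen in that place would compare.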